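Trimming a Cyclobutyl to an Ethyl on a Shared Core

This account rests on a few compounds, and the source may have more. Where it says the series, first, only, none or still open, it means among the compounds named here.

Of the compounds shown here, three built on one shared core have been measured in an assay on isolated protein for displacement of a labelled ligand from melanin-concentrating hormone receptor 1 (Homo sapiens); a lower number here means a stronger inhibitor, a higher number a weaker inhibitor. Compound 1 `CCCc1cc(N2CCCC2)c2cc(NC(=O)/C=C/c3ccc(C(F)(F)F)cc3)ccc2n1` gives 17 nM. Compound 3 `CCCc1cc(N2CCC2)c2cc(NC(=O)/C=C/c3ccc(C(F)(F)F)cc3)ccc2n1` gives 2.8 nM. These two differ in one place only, and the step is a 6.1-fold lower number from compound 1 to compound 3 (0.78 log units; beyond the scatter). Compound 2 `Nc1cc(C2CCC2)nc2ccc(NC(=O)/C=C/c3ccc(C(F)(F)F)cc3)cc12` gives 2 nM, the lowest number of the three; it lies within the scatter of compound 3 but well beyond that of compound 1. Compound 2 and compound 3 differ in two places at once, so their values can only be set side by side.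

Compound 4 `CCc1cc(N)c2cc(NC(=O)/C=C/c3ccc(C(F)(F)F)cc3)ccc2n1` has not yet been measured. It departs from compound 2 by a single change: ethyl in place of cyclobutyl on an aromatic carbon. Among the compounds with values here, the one measured step, from compound 1 to compound 3, shrank a ring on the core and came with a lower number; here a ring is removed altogether and a chain put in its place, a change of a different kind, so that step bears only loosely. For compound 4 a small rise in number is expected, a 2.5-fold higher number from compound 2 to compound 4 (0.40 log units; beyond the scatter). Compound 4 is therefore estimated at 5 nM, with a range from 1.5 nM to 20 nM.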

Compound 4, half-maximal inhibitory concentration: 1.2 nM
Compound 4: middle estimate off by 4.2-fold (0.62 log units), on the high side, outside the stated range (below it).
By their numbers in this assay, from the lowest: compounds 4, 2 and 3 (each within the scatter of the next, the first and the last beyond it); then compound 1.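

In this assay, swapping cyclobutyl for ethyl on this aromatic carbon next to the ring nitrogen gives a 1.7-fold lower number from compound 2 to compound 4 (0.22 log units; within the scatter) and so leaves the two compounds indistinguishable. On this core, with the amino group in place, the four-membered carbon ring is therefore not needed for a low number: an open ethyl chain with two heavy atoms instead of four serves just as well. No measurement shown here bears on why the two groups match.

Still open, from the compounds shown here alone, is how far this position's freedom extends, for instance whether a methyl, a longer chain such as butyl, or a branched tert-butyl group would also stay within the scatter of compound 4. Equally open, going by these compounds, is whether the same swap would give so small a step with pyrrolidin-1-yl or azetidin-1-yl on the core in place of the amino group.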